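This account rests on a few compounds, and the source may have more. Where it says the series, first, only, none or still open, it means among the compounds named here.

The series is followed in a functional assay on Raji cells (Homo sapiens) for antiproliferative activity; on this read-out higher numbers stand for weaker inhibition and lower numbers for stronger inhibition. Compound 1 `COP1(=O)OC[C@H]2O[C@@H](n3cc(Br)c(=O)[nH]c3=O)C[C@@H]2O1` gives only a limit in this assay, > 100 ug/mL, which is the limit of > 100 ug/mL in this assay, at which 1 of the 3 values shown sits. Among the measured compounds shown here, compound 2 `O=c1[nH]c(=O)n([C@H]2C[C@H](O)[C@@H](COP(=O)(O)O)O2)cc1C(F)(F)F` gives 212 ug/mL in this assay, the one value shown that is a number rather than a limit. Compound 3 `O=c1[nH]c(=O)n([C@H]2C[C@@H]3O[PH](O)(O)OC[C@H]3O2)cc1Br` likewise gives only a limit in this assay, > 1000 ug/mL, which is the limit of > 1000 ug/mL in this assay, at which 1 of the 3 values shown sits. Compound 3 thus stands at a limit, and one further value shown is a limit as well, so nothing in the shown numbers places compound 3 against compound 2 beyond the fact that compound 2 alone gives a number.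

Compound 4 `O=c1[nH]c(=O)n([C@H]2C[C@@H]3O[PH](O)(O)OC[C@H]3O2)cc1I`, not yet measured, differs from compound 3 by iodo in place of bromo on an aromatic carbon. For the measured compounds named here, no step between two measured compounds is available, so the change from bromo to iodo at this place has no measured counterpart. The expected step of a number no higher from compound 3 to compound 4 (the limit leaves the size open) is none beyond the scatter. For compound 4 the estimate in this assay is 1000 ug/mL, with a range from 300 ug/mL to 3000 ug/mL, and a limit rather than a number is the likelier report.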

Compound 4, concentration for 50% inhibition: > 500 ug/mL
Compound 4 ended at the assay's limit; the forecaster's own chance of this, stated with the estimate: 80%; the middle value does not contradict the limit.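

In this assay compound 3 gives > 1000 ug/mL, a limit. Compound 4 gives > 500 ug/mL, also a limit. No step can be read between compound 3 and compound 4. The compounds shown leave open whether iodo in place of bromo on an aromatic carbon changes antiproliferative activity at all.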